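The source may report more compounds than this note shows. Statements on the series, on what has been measured and on what is new or still open speak of the compounds shown alone.

Measured compounds:
compound 1 `CN(C)CC[C@H]1CCC[C@@H](c2ccccc2)C1`: 10 nM
compound 2 `c1ccc(CNCC[C@H]2CCC[C@@H](c3ccccc3)C2)cc1`: 1.3 nM

Both were tested in an assay on membranes from brain for displacement of a labelled ligand from Sigma non-opioid intracellular receptor 1 (Cavia porcellus), read by scintillation counting, with a stated time of 120 min; on this read-out higher numbers stand for weaker inhibition and lower numbers for stronger inhibition. Compound 2 gives 1.3 nM, the lower of the two numbers; compound 1 gives 10 nM, and the gap between the two lies beyond the usual scatter. Compound 3 `NCC[C@H]1CCC[C@@H](c2ccccc2)C1` has not yet been measured in this assay. It differs from compound 2 in one place: hydrogen in place of benzyl on an amine nitrogen. Going by the values given here, the amine nitrogen of compound 3 therefore carries hydrogen where compound 2 carries benzyl, with the saturated chain carbon as its only heavy neighbour. Among the compounds with values here, no measured pair shows this same change, so the expected size of the step rests only on the two numbers known. Compound 2, with benzyl on the nitrogen, holds the lowest number, and compound 1, with the nitrogen substituted otherwise, already gives the higher value of 10 nM. Taking the benzyl away entirely is expected to move the number further in the direction of weaker inhibition, beyond the scatter. The expected step is a 46-fold higher number from compound 2 to compound 3 (1.66 log units; beyond the scatter). For compound 3 the estimate in this assay is 60 nM, with a range from 12 nM to 300 nM.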

Compound 3, inhibition constant: 138 nM
Beside the measured number, compound 3's estimate is 2.3-fold (0.36 log units) below it; measured number inside the range.
By their numbers in this assay, from the lowest: compound 2; then compound 1; then compound 3.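

In this assay, the series now includes an amine nitrogen carrying no carbon substituent beyond the saturated chain carbon, and hydrogen in place of benzyl on that nitrogen gives a 110-fold higher number from compound 2 to compound 3 (2.03 log units; beyond the scatter). Amino in place of dimethylamino at the same place gives a 14-fold higher number from compound 1 to compound 3 (1.14 log units; beyond the scatter), so both of the substituted amines hold lower numbers than the unsubstituted amino compound, and no compound shown goes against this within these three. The size of both steps shows that the substituents on this nitrogen strongly affect the read-out, but no measurement at hand explains either step.

The compounds shown leave open where a single methyl, a phenethyl group or a cyclohexylmethyl group on the amine nitrogen would fall relative to the amino, dimethylamino and benzyl compounds. Also open, as far as these compounds go, is how an acetyl group on that nitrogen, which would turn the amine into an amide, would read in this assay.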